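The compounds below may be only part of what the source reports. "The series", "measured", "known", "first", "only" and "open" are said of these compounds alone.

Working notes on the series. Compound 1 `CC(C)C[C@H](N)c1cc(C(F)(F)F)ccc1N1CCN(C(=O)CC(C)C(=O)c2ccc(Cl)cc2)CC1` gives 1100 nM in an assay on HEK293 cells for displacement of a labelled ligand from Melanocortin receptor 4 (Homo sapiens) (a lower number here means a stronger inhibitor, a higher number a weaker inhibitor), the highest of the three numbers measured. Compound 3 `CC(C)C[C@H](N)c1ccccc1N1CCN(C(=O)[C@H](C)Cc2ccc(Cl)cc2Cl)CC1` gives 16 nM in this assay and compound 2 `COc1cc(Cl)ccc1C[C@@H](C)C(=O)N1CCN(c2ccc(C)cc2[C@@H](N)CC(C)C)CC1` gives 8.1 nM; both gaps to compound 1 lie beyond the usual scatter, the gap to compound 3 being the narrower one. Compound 4 `CC(C)C[C@H](N)c1cc(C(F)(F)F)ccc1N1CCN(C(=O)COc2cccc3ccccc23)CC1` has not yet been measured. It differs from compound 1 by (naphthalen-1-yl)oxy in place of 1-((4-chlorophenyl)carbonyl)ethyl on a saturated chain carbon bound to a carbonyl carbon. For the measured compounds named here, no measured pair shows this change, and the core of compound 1 is not shared by compound 2 or compound 3. A moderate gain in this assay is expected, since compound 1 stands far above the other two. The value expected for compound 4 is 400 nM, within 80 nM to 2000 nM, a step of a 2.8-fold lower number from compound 1 to compound 4 (0.44 log units; beyond the scatter).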

Compound 4, inhibition constant: 2600 nM
The estimate for compound 4 lay 6.5-fold (0.81 log units) below the measured number, outside the stated range (above it).
By their numbers in this assay, from the lowest: compounds 2 and 3 (each within the scatter of the next); then compound 1; then compound 4.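

In this assay this first comparison on a saturated chain carbon bound to a carbonyl carbon gives a 2.4-fold higher number from compound 1 to compound 4 (0.37 log units; beyond the scatter) for (naphthalen-1-yl)oxy in place of 1-((4-chlorophenyl)carbonyl)ethyl, so this change brings no gain on this core. The two groups match in heavy atoms and hydrogen-bond acceptors, yet the number still moves, so those counts alone do not set the value here. Nothing at hand accounts for the step.

Going by these compounds, whether an amine or a carboxylic acid at this place would lower the number remains open. Also open, on these data alone, is whether the step carries over to the cores of compound 2 and compound 3.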